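A few compounds are considered here, and "the series" means these few. Any claim that something is new, unique, unknown or untested is made for them only; others in the source may bear on it.

Compounds measured in a functional assay on the whole organism (strain BALB/c) for inhibition, with Mus musculus as the target, read by paw edema, with a stated time of 4 h, at a dose of 50 mg/kg by the oral route; a lower number here means less inhibition, a higher number more inhibition at the dose given (going by the name of the read-out):

Compound 1 `CNc1nnc(-c2cc(-c3ccc(F)cc3F)ccc2O)o1` gives 41.4%.
Compound 2 `C=CCNc1nnc(-c2cc(-c3ccc(F)cc3F)ccc2O)o1` gives 36.6%.
Compound 3 `C=CCNc1nnc(-c2cc(-c3ccc(F)cc3F)ccc2O)s1` gives 57.2%.

Compound 3 stands highest of the three in this assay; compound 1 lies nearest to it, a number beyond the scatter lower, and compound 2 lies furthest, also beyond the scatter lower. Compound 4 `CNc1nnc(-c2cc(-c3ccc(F)cc3F)ccc2O)s1` has not yet been measured in this assay. It differs from compound 3 in one place: hydrogen in place of vinyl on a saturated chain carbon bound to a nitrogen on an aromatic ring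

Among the measured compounds shown here, only one measured step bears on this change. Between compound 1 and compound 2, which share the other core, the same pair of groups is exchanged in the opposite direction: a number 4.8 percentage points lower from compound 1 to compound 2 (within the scatter). Read backwards, that step says replacing vinyl by hydrogen on the saturated chain carbon bound to the ring nitrogen brought no shift beyond the scatter on that core. For the measured compounds named here, on the core of compound 3 there is no measured pair for this change, so the expectation rests on that single step alone. Compound 4 is therefore expected to give a value close to that of compound 3, with a step of a number 2.8 percentage points higher from compound 3 to compound 4 (within the scatter) that stays within the scatter. The estimate for compound 4 in this assay is 60%, within a range from 46% to 74%.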

Compound 4, a percentage reported as inhibition, in the whole organism at one dose (the size of the read-out at that dose, not a potency): 45.4%
Estimate against measurement, compound 4: 14.6 percentage points above; measured number below the stated range.
By their numbers in this assay, from the lowest: compounds 2, 1 and 4 (each within the scatter of the next); then compound 3.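

In this assay, the change from allylamino to methylamino proves not to be neutral on the core of compound 3, where the step reads a number 11.8 percentage points lower from compound 3 to compound 4 (beyond the scatter). What this position contributes therefore depends on the core that carries it, and the earlier pair alone could not show this: the same change on two cores in this assay, a number 4.8 percentage points lower (within the scatter) from compound 1 to compound 2 and a number 11.8 percentage points higher (beyond the scatter) from compound 4 to compound 3, 16.6 percentage points apart, beyond the scatter of two such steps. The exchange of 5-(methylamino)-1,3,4-oxadiazol-2-yl for 5-(methylamino)-1,3,4-thiadiazol-2-yl on an aromatic carbon, with the methyl group kept on the nitrogen, gives a number 4 percentage points higher from compound 1 to compound 4 (within the scatter), so with this smaller chain the two cores are not told apart in this read-out.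

As far as these compounds go, it remains open whether an ethyl group, a longer saturated chain or a chain ending in an amine or a carboxylic acid would separate the two cores as allyl does, or whether the separation holds for allyl alone. All of these numbers come from a single dose and a single time, so they leave open whether the gap on the core of compound 3 would persist at other doses or reflects a difference in potency.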